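This account rests on a few compounds, and the source may have more. Where it says the series, first, only, none or still open, it means among the compounds named here.

Measured so far in a functional assay on NPC-TW01 cells (Homo sapiens) for inhibition, read by MTT assay, with a stated time of 72 h; a lower number here means a stronger inhibitor of growth, a higher number a weaker inhibitor of growth:
compound 1 `Nc1cc(-c2ccc(Cl)cc2)nn1-c1ccc(Br)cc1` gives 64400 nM
compound 2 `CN(C)/C=N/c1c(C=O)c(-c2ccccc2)nn1-c1ccccc1` gives 9300 nM
compound 3 `CN(C)/C=N/c1cc(-c2ccc(Cl)cc2)nn1-c1ccc(Br)cc1` gives 60700 nM

Compound 2 has the lowest number of the three; its values against compound 3 and compound 1 both sit beyond the scatter. The difference between the cores of compound 2 and compound 3 is not broken down here.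

One change recurs in the series. From compound 3 to compound 1 it is one nitrogen atom in place of a group of 5 heavy atoms (3 carbon, 2 nitrogen; no ring), on an aromatic carbon and the step is a 1.1-fold higher number from compound 3 to compound 1 (0.03 log units; within the scatter). Compound 4 `Nc1c(C=O)c(-c2ccccc2)nn1-c1ccccc1`, not yet measured, arises from compound 2 by the same kind of change, (one nitrogen atom in place of a group of 5 heavy atoms (3 carbon, 2 nitrogen; no ring), on an aromatic carbon); the surroundings differ, as the ring there carries a formyl group and a phenyl group rather than a 4-bromophenyl and a 4-chlorophenyl group.

Because a 1.1-fold higher number from compound 3 to compound 1 (0.03 log units; within the scatter) lies within the scatter, the expected step is a 1.1-fold higher number from compound 2 to compound 4 (0.03 log units; within the scatter). Compound 4 is estimated at 10000 nM, between 4000 nM and 25000 nM.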

Compound 4, concentration for 50% growth inhibition: > 100000 nM
Compound 4: no number, only a limit; the forecaster's own chance of this, stated with the estimate: 5%; middle value at least 10-fold (1.00 log units) from the limit.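

On the core of compound 2, exchanging the group of 5 heavy atoms for amino gives an at least 10-fold higher number from compound 2 to compound 4 (1.03 log units; beyond the scatter), so the near-silent result on the other core does not carry over in this assay: the same change on two cores in this assay, a 1.1-fold higher number (0.03 log units; within the scatter) from compound 3 to compound 1 and an at least 10-fold higher number (1.03 log units; beyond the scatter) from compound 2 to compound 4, at least 10-fold (1.00 log units) apart, beyond the scatter of two such steps

Compound 4 gives > 100000 nM, which is a limit of the assay and not a number: the limit of > 100000 nM in this assay, at which 1 of the 4 values shown sits.

The two pairs do not show which difference between the cores, the formyl group or the phenyl groups against the 4-bromophenyl and 4-chlorophenyl groups, goes with the divergence, and they say nothing about a third core.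

Open, as far as these compounds go, is whether the formyl group alone decides the outcome. A nitrile or a carboxylic acid in its stead, or a methylamino or acetamide group in place of amino, lies outside the compounds shown.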